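Removing a Phenyl from an Aryl Ether in Two Parallel Steps

The source may hold more compounds than are shown below. What is called first, only, known or untested is meant among the compounds shown, and "the series" means these compounds.

compound 2 `C=CC(C)(C/C=C(\C)CCC=C(C)C)c1ccc(O)c(OCc2ccccc2)c1`: 18.6 ug/mL
compound 3 `C=CC(C)(C/C=C(\C)CCC=C(C)C)c1ccc(O)c(OC)c1`: > 25 ug/mL
compound 1 `C=CC(C)(C/C=C(\C)CCC=C(C)C)c1ccc(OCc2ccccc2)c(O)c1`: "not determined" (no result reported)

In a functional assay on MDA-MB-435 cells (Homo sapiens) for cytotoxicity, read by MTT assay, with a stated time of 72 h (a lower number here means a stronger inhibitor, a higher number a weaker inhibitor), compound 2 gives 18.6 ug/mL. For compound 3 this assay reports only a limit, > 25 ug/mL. For compound 1 no result is reported in this assay, "not determined" (no result reported). Compound 3 arises from compound 2 by hydrogen in place of phenyl on a saturated chain carbon bound to an oxygen on an aromatic ring, and that step reads an at least 1.3-fold higher number from compound 2 to compound 3 (0.12 log units; that floor lies within the scatter); its floor comes from the limit of > 25 ug/mL in this assay, at which 1 of the 3 values shown sits. Compound 4 `C=CC(C)(C/C=C(\C)CCC=C(C)C)c1ccc(OC)c(O)c1` arises from compound 1 by the same change, (hydrogen in place of phenyl on a saturated chain carbon bound to an oxygen on an aromatic ring); the difference between the two cores is not broken down here. As the floor of the measured step lies within the scatter, the data do not show whether this change weakens or strengthens. Compound 4 is expected near 30 ug/mL, roughly between 12 ug/mL and 70 ug/mL, resting on an at least 1.3-fold higher number from compound 2 to compound 3 (0.12 log units; that floor lies within the scatter) and the chance that only a limit is returned.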

Compound 4, half-maximal inhibitory concentration: > 25 ug/mL
Compound 4 was reported as a limit; the forecaster's own chance of this, stated with the estimate: 65%; the middle value does not contradict the limit.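

With no number for compound 1 in this assay and only a limit for compound 4, no new step can be read between them. The compounds shown leave open whether changing benzyloxy to methoxy weakens or strengthens activity on either core.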